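The source may hold more compounds than are shown below. What is called first, only, known or untested is meant among the compounds shown, and "the series" means these compounds.

In an ADME assay on a cell-free system (plasma, Rattus norvegicus) for protein binding, compound 2 (`CNc1nccc(N2CC[C@H](NC(=O)Nc3ccc(CN4CCC4)c(C(F)(F)F)c3)C2)n1`) gives 89.2%. This lies within the scatter of compound 1 (`CNc1nccc(N2CC[C@H](NC(=O)Nc3ccc(CN(C)C)c(C(F)(F)F)c3)C2)n1`), which gives 91%, whereas compound 3 (`Nc1nccc(N2CC[C@H](NC(=O)Nc3ccc(Cl)c(C(F)(F)F)c3)C2)n1`) gives 99.4%, a far smaller unbound fraction and a gap beyond the scatter. Compound 4 (`CNc1nccc(N2CC[C@H](NC(=O)Nc3ccc(CN4CCN(C)CC4)c(C(F)(F)F)c3)C2)n1`) differs from compound 2 in one place: 4-methylpiperazin-1-yl in place of azetidin-1-yl on a saturated chain carbon bound to an aromatic carbon. Among the compounds with values here, only one measured step bears on this place, the exchange of dimethylamino for azetidin-1-yl, a 1.2-fold higher unbound fraction from compound 1 to compound 2 (0.08 log units; within the scatter), which stays within the scatter. Within the data shown here, no measured compound yet carries the larger six-membered ring, so this precedent is limited. The expected change is therefore small, with an estimated a 1.1-fold lower unbound fraction from compound 2 to compound 4 (0.03 log units; within the scatter) and no clear direction beyond the scatter. For compound 4 the estimated value in this assay is 90%, with an expected range from 80% to 96%.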

Compound 4, plasma protein binding: 85.1%
Compound 4: middle estimate off by 1.5-fold (0.17 log units) (unbound fraction), on the low side; low and high end bracket the measured number.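

In this assay the exchange of azetidin-1-yl for 4-methylpiperazin-1-yl gives a 1.4-fold higher unbound fraction from compound 2 to compound 4 (0.14 log units; within the scatter) on this saturated chain carbon, and the exchange of dimethylamino for the same ring gives a 1.7-fold higher unbound fraction from compound 1 to compound 4 (0.22 log units; within the scatter) at this place. The earlier pair could not show this for a six-membered ring with a second nitrogen: all three amines now stand within the scatter of one another. On these data alone, how a carboxylic acid or a longer chain ending in an amine would read at this place remains open. Nothing shown gives a measured reason for these steps.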